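The compounds below may be only part of what the source reports. "The series", "measured", "known", "first", "only" and "open" are said of these compounds alone.

Measured so far in a functional assay on HepG2 cells (Homo sapiens) for antiproliferative activity, read by MTT assay, with a stated time of 48 h; on this read-out higher numbers stand for weaker inhibition and lower numbers for stronger inhibition:

- compound 1 `Cc1ccc(-c2nc(N)c3cc(Cl)ccc3n2)cc1` gives 14.5 ug/mL
- compound 2 `Cc1ccc(-c2nc(NO)c3cc(Cl)ccc3n2)cc1` gives 23.1 ug/mL
- compound 3 `Cc1ccc(-c2nc(NC(=O)c3ccccc3)c3cc(Cl)ccc3n2)cc1` gives 17.5 ug/mL

Compound 3 at 17.5 ug/mL lies within the scatter of both other compounds, so the three cannot be ranked. Compound 4 `CSc1nc(-c2ccc(C)cc2)nc2ccc(Cl)cc12` has not yet been measured. It carries methylsulfanyl in place of benzamido on an aromatic carbon and otherwise keeps the core of compound 3.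

Three measured steps change the group on the nitrogen attached at that carbon: a 1.6-fold higher number from compound 1 to compound 2 (0.20 log units; within the scatter) together with a 1.2-fold higher number from compound 1 to compound 3 (0.08 log units; within the scatter) and a 1.3-fold lower number from compound 2 to compound 3 (0.12 log units; within the scatter) make up all the evidence available. For the measured compounds named here, none of them removes that nitrogen, and no measured compound carries methylsulfanyl, so they bear on this change only indirectly. With a 1.2-fold higher number from compound 1 to compound 3 (0.08 log units; within the scatter) as the closest guide, since it involves the same benzoyl group, no step beyond the scatter is expected in this assay in either direction. The expected change is a 1.0-fold higher number from compound 3 to compound 4 (0.01 log units; within the scatter) and it remains only an estimate. Compound 4 is estimated at 18 ug/mL with an expected range from 9 ug/mL to 36 ug/mL in this measurement.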

Compound 4, half-maximal inhibitory concentration: 13.3 ug/mL
For compound 4 the middle estimate is 1.4-fold (0.13 log units) above the measured one; the range from low to high includes it.
By their numbers in this assay, from the lowest: compounds 4, 1, 3 and 2 (each within the scatter of the next).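

Every earlier compound kept a nitrogen on this aromatic carbon, so only the group on that nitrogen had been varied. Compound 4 has no nitrogen there and carries methylsulfanyl, with no ring and no hydrogen-bond donor, yet in this assay the change from benzamido stays within the scatter (a 1.3-fold lower number from compound 3 to compound 4 (0.12 log units; within the scatter)), as do the changes from hydroxyamino (a 1.7-fold lower number from compound 2 to compound 4 (0.24 log units; within the scatter)) and from amino (a 1.1-fold lower number from compound 1 to compound 4 (0.04 log units; within the scatter)). So at this position, in this assay, a sulfur-linked group of just 2 heavy atoms cannot be told apart from any of the three nitrogen-linked groups, and all four compounds remain unranked. No measurement shown here explains why these groups give such similar numbers.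

On these data alone, since no group at this carbon has yet moved the number beyond the scatter, it remains open whether this position can affect the read-out at all, which a longer chain such as hexylsulfanyl, a carboxylic acid or a piperazine ring could test. As far as these compounds go, the chlorine and the 4-methylphenyl group are the same in all four compounds, so their contribution also remains unknown.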